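Working notes: from compound 3 to compound 4

The source may hold more compounds than are shown below. What is called first, only, known or untested is meant among the compounds shown, and "the series" means these compounds.

Measured in a functional assay on HCT-116 cells (Homo sapiens) for inhibition, read by colorimetric assay, with a stated time of 3 days (a lower number here means a stronger inhibitor, a higher number a weaker inhibitor), with every value a limit:
- Compound 1 `C/C(=N\O)C(=O)NCCCCCC(=O)Nc1ccccc1`: > 100000 nM
- Compound 2 `O=C(CCCCCCC(O)C(F)(F)F)Nc1ccccc1`: > 40000 nM
- Compound 3 `O=C(CCCCCNC(=O)c1cc(=O)c(O)co1)Nc1ccccc1`: > 100000 nM

Compound 3 has only a limit and no number, and it stands at the limit of > 100000 nM in this assay, at which 2 of the 3 values shown sit. Compound 2 stands at the limit of > 40000 nM in this assay, at which 1 of the 3 values shown sits.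

The change to compound 4 `CC(=O)C(=O)NCCCCCC(=O)Nc1ccccc1` is a group of 3 heavy atoms (2 carbon, 1 oxygen; no ring) in place of a group of 8 heavy atoms (5 carbon, 3 oxygen; one six-membered aromatic ring with 1 hetero atom), on a carbonyl carbon. The acetyl enters on a carbonyl carbon whose other neighbours are: amide-type nitrogen.

The closest measured step is a step that the two limits leave unreadable from compound 1 to compound 3, which also falls on a carbonyl carbon. The other is a step that the two limits leave unreadable from compound 1 to compound 2. Going by the values given here, neither has a size that can be read, and no compound has yet given a number in this assay. These steps offer no support for a shift in either direction. The step expected is a number no higher from compound 3 to compound 4 (the limit leaves the size open), so none beyond the scatter. For compound 4 the estimate is 100000 nM, with an expected range of 40000 nM to 200000 nM.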

Compound 4, half-maximal inhibitory concentration: > 100000 nM
Compound 4 gave a limit, no number (the forecaster's own chance of this, stated with the estimate: 85%); the middle value sits exactly at the limit.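

Compound 4 gives > 100000 nM, which is a limit. Its steps from compound 1, compound 2 and compound 3 therefore cannot be read, as all four values are limits. The compounds shown leave open whether any change to the shared core would give a number in this assay.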